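The source may hold more compounds than are shown below. What is called first, only, known or untested is meant among the compounds shown, and "the series" means these compounds.

In an in vivo ADME assay on the whole organism (strain Sprague-Dawley) for metabolic stability, with Rattus norvegicus as the target (a higher number here means that the compound lasts longer, a lower number that the compound disappears faster), compound 1 `Cc1cc(C(C)CC(=O)O)ccc1-c1noc(-c2ccc(OC(C)C)c(C(F)(F)F)c2)n1` gives 3.1 h and compound 2 `Cc1cc(CC(C)C(=O)O)ccc1-c1noc(-c2ccc(OC(C)C)c(C(F)(F)F)c2)n1` gives 1.7 h. These two values lie within the scatter of each other, so compound 2 cannot be separated from compound 1. Compound 3 `Cc1cc(CCC(=O)O)ccc1-c1noc(-c2ccc(OC(C)C)c(C(F)(F)F)c2)n1` differs from compound 2 by hydrogen in place of methyl on a saturated chain carbon bound to a carbonyl carbon and a saturated chain carbon, which turns 2-carboxypropyl into 2-carboxyethyl. Going by the values given here, the one measured step that bears on this is a 1.8-fold lower number from compound 1 to compound 2 (0.26 log units; within the scatter), which swaps 1-(carboxymethyl)ethyl for 2-carboxypropyl and stays within the scatter. Among the compounds with values here, no measured compound lacks the methyl, so the evidence is indirect, and no change beyond the scatter is expected in this assay. The expected step is a 1.2-fold higher number from compound 2 to compound 3 (0.07 log units; within the scatter). For compound 3 the estimated half-life is 2 h, with an expected range from 1 h to 3.8 h.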

Compound 3, half-life: 1.1 h
Compound 3: middle estimate off by 1.8-fold (0.26 log units), on the high side; the range from low to high includes it.
By their numbers in this assay, from the lowest: compounds 3, 2 and 1 (each within the scatter of the next, the first and the last beyond it).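

In this assay, hydrogen in place of methyl on the saturated chain carbon bound to a carbonyl carbon gives a 1.5-fold lower number from compound 2 to compound 3 (0.19 log units; within the scatter) and leaves compound 2 and compound 3 inseparable, so this methyl can go without a change that stands clear of the scatter. Hydrogen in place of methyl on the saturated chain carbon bound to an aromatic carbon gives a 2.8-fold lower number from compound 1 to compound 3 (0.45 log units; beyond the scatter), the first step in this series beyond the scatter, though a modest one. No measurement at hand accounts for this result.

From the compounds shown here alone, whether an ethyl group or a fluorine atom on either chain carbon would give a longer or shorter half-life remains open. So does the effect of a longer chain carrying the carboxylic acid, or of an amide in its place.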